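Hydroxyphenyl placement on the shared core: working notes

The source may hold more compounds than are shown below. What is called first, only, known or untested is meant among the compounds shown, and "the series" means these compounds.

Measured so far:
compound 1, `Oc1cccc(-c2cc(-c3ccc(F)cc3)cc(-c3ccccc3O)n2)c1`, gives a limit of > 50000 nM in a functional assay on DU-145 cells (Homo sapiens) for inhibition; on this read-out lower numbers stand for stronger inhibition and higher numbers for weaker inhibition.
compound 2, `Oc1ccc(-c2cc(-c3ccc(F)cc3)cc(-c3ccccc3O)n2)cc1`, gives a limit of > 50000 nM in this assay.
compound 3, `Oc1ccc(-c2cc(-c3ccccc3F)cc(-c3cccc(O)c3)n2)cc1`, gives 3160 nM in this assay.

The value for compound 1 is a limit of this assay, not a number. The value for compound 2 is likewise a limit. Between them stands one change, (4-hydroxyphenyl in place of 3-hydroxyphenyl on an aromatic carbon), and the step that the two limits leave unreadable from compound 1 to compound 2 cannot be sized, since both ends sit at the limit of > 50000 nM in this assay, at which 2 of the 3 values shown sit. For the measured compounds named here, compound 3 supplies the only number in the set; how its core differs from that of compound 1 is not broken down here.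

Compound 4, `Oc1ccc(-c2cc(-c3ccccc3F)cc(-c3ccc(O)cc3)n2)cc1`, is still to be measured in this assay. It differs from compound 3 by 4-hydroxyphenyl in place of 3-hydroxyphenyl on an aromatic carbon. This is the same kind of change as that from compound 1 to compound 2, but the surroundings differ: in compound 3 the place is meta to a 2-fluorophenyl group and meta to a 4-hydroxyphenyl group, whereas in compound 1 it is meta to a 2-hydroxyphenyl group and meta to a 4-fluorophenyl group.

With the earlier step unreadable, no direction is supported, so the expected step from compound 3 to compound 4 is a 1.3-fold higher number from compound 3 to compound 4 (0.10 log units; within the scatter), centred near no change. Compound 4 is therefore estimated at 4000 nM, with a range from 1000 nM to 20000 nM.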

Compound 4, half-maximal inhibitory concentration: 7780 nM
Estimate against measurement, compound 4: 1.9-fold (0.29 log units) below; the range from low to high includes it.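

In this assay, setting 4-hydroxyphenyl in place of 3-hydroxyphenyl on the core of compound 3 gives a 2.5-fold higher number from compound 3 to compound 4 (0.39 log units; beyond the scatter), so on this core the change costs a modest amount of inhibition. On the core of compound 1 the same change cannot be read, as compound 1 and compound 2 both stand at a limit of the assay and not at a number: the limit of > 50000 nM in this assay, at which 2 of the 4 values shown sit. The series therefore holds a single readable instance of this change, which shows its direction and size on one core only and does not show whether the step carries over to the other core, where a shift of either direction would stay hidden behind the limits.

Going by these compounds, compound 1 and compound 3 differ in more than one place, so which of those differences separates a limit from a measured number remains open. Also open, on these data alone, is how the place next to the ring nitrogen responds to a group other than a hydroxyphenyl, such as an aminophenyl or a phenyl bearing a carboxylic acid, on either core.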